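The source may hold more compounds than are shown below. What is called first, only, known or untested is meant among the compounds shown, and "the series" means these compounds.

Compound 1, `CC[C@@H](CCn1cncn1)c1ccc(C)cc1`: 79.4 ug/mL
Compound 2, `CCCC[C@@H](CCn1cncn1)c1ccc(F)cc1`: 34.1 ug/mL
Compound 3, `CCCC[C@H](CCn1cncn1)c1ccc(C)cc1`: 26.5 ug/mL

All three were read in an ADME assay on RD cells (Homo sapiens) for cytotoxicity, read by MTT assay, with a stated time of 3 days; on this read-out higher numbers stand for lower toxicity in this test and lower numbers for higher toxicity in this test. Compound 3 gives the lowest of the three numbers. Compound 2 stands nearest to it and within the scatter, so no order between compound 3 and compound 2 can be claimed; compound 1 stands furthest and beyond the scatter, a higher number than compound 3.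

Compound 4, `CCCC[C@@H](CCn1cncn1)c1ccc(C)cc1`, is the companion of compound 3: the two compounds have the same atoms and bonds and differ only in configuration as drawn: 1 of 1 stereo elements differ; a stereocentre at a saturated chain carbon is drawn R in compound 3 and S in compound 4. Among the compounds with values here, no pair of measured compounds differs in this way alone, so no measured step of this kind exists here. The step of a 1.1-fold higher number from compound 3 to compound 4 (0.02 log units; within the scatter) is expected to lie within the scatter, in no particular direction. Compound 4 is therefore estimated at 28 ug/mL, with a range from 13 ug/mL to 60 ug/mL.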

Compound 4, half-maximal cytotoxic concentration: 56.5 ug/mL
Beside the measured number, compound 4's estimate is 2.0-fold (0.30 log units) below it; the measured number falls inside the stated range.
By their numbers in this assay, from the lowest: compounds 3, 2, 4 and 1 (each within the scatter of the next, the first and the last beyond it).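

In this assay the configuration at this saturated chain carbon can now be read, with a 2.1-fold higher number from compound 3 to compound 4 (0.33 log units; beyond the scatter) and the gap can be assigned to that stereocentre alone because of one fact: the fact that compounds 3 and 4 differ only in the configuration as drawn. Methyl in place of fluoro on an aromatic carbon gives a 1.7-fold higher number from compound 2 to compound 4 (0.22 log units; within the scatter) and ethyl in place of hydrogen on a saturated chain carbon, three bonds along the chain from an aromatic carbon, gives a 1.4-fold lower number from compound 1 to compound 4 (0.15 log units; within the scatter) so neither change can be read as moving the number. As far as these compounds go, whether compound 1 and compound 2 would show a similar gap between their two configurations stays open, as does what chloro in place of methyl on the aromatic carbon would give.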